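The source may report more compounds than this note shows. Statements on the series, on what has been measured and on what is new or still open speak of the compounds shown alone.

Measured so far in a functional assay on PC-3 cells (Homo sapiens) for cytotoxicity, read by MTT assay; a lower number here means a stronger inhibitor, a higher number a weaker inhibitor:

- compound 1 `Cc1nc(Nc2ccccc2)sc1C(=O)/C=C/c1ccc(Cl)cc1`: compound 1 gives > 25000 nM, which is a limit of the assay.
- compound 2 `Cc1ccccc1Nc1nc(C)c(C(=O)/C=C/c2ccc(Cl)cc2)s1`: compound 2 gives > 25000 nM, which is a limit of the assay.
- compound 3 `Cc1ccc(Nc2nc(C)c(C(=O)/C=C/c3ccc(Cl)cc3)s2)cc1`: compound 3 gives > 25000 nM, which is a limit of the assay.

Compound 3 therefore stands only at a limit in this assay; the two further values shown are limits as well, all three sitting at the same boundary (the limit of > 25000 nM in this assay, at which 3 of the 3 values shown sit). The steps among the measured compounds, from compound 1 to compound 2 a step that the two limits leave unreadable from compound 1 to compound 2, from compound 1 to compound 3 a step that the two limits leave unreadable from compound 1 to compound 3 and from compound 2 to compound 3 a step that the two limits leave unreadable from compound 2 to compound 3, give no readable size, since both ends of each sit at a limit.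

Compound 4 `Cc1nc(Nc2cccc(Cl)c2)sc1C(=O)/C=C/c1ccc(Cl)cc1` differs from compound 3 by 3-chlorophenyl in place of 4-methylphenyl on a nitrogen on an aromatic ring. The nearest measured steps are the two exchanges on the phenyl on the ring nitrogen, from compound 1 to compound 2 and from compound 2 to compound 3, and neither yields a number in this assay. There is thus no measured basis for any step beyond the scatter, in either direction. The step from compound 3 to compound 4 is expected to be about a step that the limit leaves unreadable from compound 3 to compound 4, with the outcome most likely again a limit. For compound 4 the expected value in this assay is 35000 nM, in the range 10000 nM to 120000 nM.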

Compound 4, half-maximal inhibitory concentration: > 25000 nM
Compound 4: only a limit was reported; the forecaster's own chance of this, stated with the estimate: 80%; the middle value is on the limit's open side.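

In this assay compound 4 gives > 25000 nM as a limit of the assay. For the compounds shown here, no step among compound 1, compound 2, compound 3 and compound 4 can be read, because all of them sit at one boundary: the limit of > 25000 nM in this assay, at which 4 of the 4 values shown sit.

The compounds shown leave open whether any exchange on the phenyl on the nitrogen changes the read-out in this assay at all.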